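The source may hold more compounds than are shown below. What is called first, only, known or untested is meant among the compounds shown, and "the series" means these compounds.

Compound 1 `CCn1c(C(=O)NCCNC(=O)OC(C)(C)C)ccc1C(CC)(CC)c1ccc(OCS(=O)(=O)c2ccccc2)c(C)c1`: > 50000 nM
Compound 2 `CCn1c(C(=O)N[C@@H](C)C(=O)O)ccc1C(CC)(CC)c1ccc(OCS(=O)(=O)c2ccccc2)c(C)c1`: 20800 nM

Going by the values given here, in a functional assay on BXPC-3 cells (Homo sapiens) for antiproliferative activity, read by MTT assay, with a stated time of 24 h (a higher number here means a weaker inhibitor, a lower number a stronger inhibitor), compound 2 gives 20800 nM, the only true number so far. The entry for compound 1 is a limit of the assay, not a number.

Compound 3 `CCn1c(C(=O)NCC(=O)O)ccc1C(CC)(CC)c1ccc(OCS(=O)(=O)c2ccccc2)c(C)c1` differs from compound 2 by hydrogen in place of methyl on a saturated chain carbon bound to an amide-type nitrogen and a carbonyl carbon. Among the compounds with values here, the one measured step, an at least 2.4-fold lower number from compound 1 to compound 2 (0.38 log units; beyond the scatter), is modest and swaps a whole group on the amide-type nitrogen, so it does not directly measure this smaller change. No shift beyond the scatter is therefore expected. The expected step is a 1.1-fold higher number from compound 2 to compound 3 (0.02 log units; within the scatter). For compound 3 the estimated value is 22000 nM, with an expected range of 9000 nM to 50000 nM.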

Compound 3, half-maximal inhibitory concentration: > 50000 nM
Compound 3 was reported as a limit; the forecaster's own chance of this, stated with the estimate: 25%; at least 2.2-fold (0.35 log units) between middle value and limit.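

Taking away the single methyl on the saturated chain carbon bound to an amide-type nitrogen and a carbonyl carbon is not a silent change in this assay, as it gives an at least 2.4-fold higher number from compound 2 to compound 3 (0.38 log units; beyond the scatter). The step from compound 1 to compound 3 cannot be read, since both entries are limits. The full size of the loss from compound 2 also stays unknown because the read-out stops at a limit: the limit of > 50000 nM in this assay, at which 2 of the 3 values shown sit.

As far as these compounds go, whether an ethyl or benzyl group on that same carbon would give a lower number than compound 2 remains open.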